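From a Fluorinated Phenyl to a Pyridyl Amide Substituent

The source may hold more compounds than are shown below. What is called first, only, known or untested is meant among the compounds shown, and "the series" means these compounds.

Two compounds have been measured in an assay on T47D cells for inhibition of 17-beta-hydroxysteroid dehydrogenase type 1 (Homo sapiens), read by HPLC, with a stated time of 24 h; on this read-out lower numbers stand for stronger inhibition and higher numbers for weaker inhibition:
compound 1 `Cc1ccccc1N(C)C(=O)c1ccc(-c2ccc(O)c(F)c2)o1` gives 10 nM;
compound 2 `Cc1cccc(F)c1N(C)C(=O)c1ccc(-c2ccc(O)cc2)o1` gives 120 nM.

Compound 2 therefore has the higher of the two numbers, and its gap to compound 1 lies beyond the scatter, so compound 2 is the weaker inhibitor of the pair. For the measured compounds named here, the two structures differ in more than one place, and no single step between them has been measured.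

Compound 3 `Cc1cccnc1N(C)C(=O)c1ccc(-c2ccc(O)cc2)o1` is the next compound to be tested. Relative to compound 2 the change is 3-methylpyridin-2-yl in place of 2-fluoro-6-methylphenyl on an amide-type nitrogen. Going by the values given here, no measured pair shows this change, so the data give no direction for it. In this assay compound 3 is expected to give 150 nM, within a range of 50 nM to 500 nM. The expected step of a 1.3-fold higher number from compound 2 to compound 3 (0.10 log units; within the scatter) is thus none beyond the scatter.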

Compound 3, half-maximal inhibitory concentration: 1100 nM
Estimate against measurement, compound 3: 7.3-fold (0.87 log units) below; the measured number lies above the stated range.
By their numbers in this assay, from the lowest: compound 1; then compound 2; then compound 3.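

In this assay, for the compounds shown here, the place on the amide-type nitrogen proves sensitive to this change: 3-methylpyridin-2-yl in place of 2-fluoro-6-methylphenyl gives a 9.2-fold higher number from compound 2 to compound 3 (0.96 log units; beyond the scatter) and is the only single-place step available so far. The change removes the fluorine and brings in a ring nitrogen, counted as a hydrogen-bond acceptor, both at once, so this step cannot be assigned to either alone. Nothing at hand explains the weaker inhibition by compound 3.

The compounds shown do not separate the loss of the fluorine from the entry of the ring nitrogen. Going by these compounds, how 2-chloro-6-methylphenyl or a 3-methoxypyridin-2-yl group would fare at this place also remains open.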